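A few compounds are considered here, and "the series" means these few. Any claim that something is new, unique, unknown or untested is made for them only; others in the source may bear on it.

Compound 3 `COc1cc2ncnc(-n3nc(-c4ccccn4)nc3N)c2cc1OCCCNC(=O)OC(C)C` stands second highest of the three numbers in a physicochemical assay for solubility, in phosphate buffer, with a stated time of 18 h, at pH 7.4 (a lower number here means a less soluble compound, a higher number a more soluble compound), where compound 3 gives 18000 nM. Compound 1 `COc1cc2ncnc(-n3nc(-c4ccccn4)nc3N)c2cc1OCCCN1CC(C)OC(C)C1` gives 8000 nM, and compound 2 `CCN(CC)C(=O)COc1cc2c(-n3nc(-c4ccccn4)nc3N)ncnc2cc1OC` gives 42000 nM. Compound 4 `COc1cc2ncnc(-n3nc(-c4ccccn4)nc3N)c2cc1OCCCNC(=O)C(F)(F)F` differs from compound 3 by trifluoromethyl in place of isopropoxy on a carbonyl carbon. Going by the values given here, no measured step makes this exchange at the carbonyl carbon, so none bears on it directly; the steps that reach compound 3, a 2.3-fold higher number from compound 1 to compound 3 (0.35 log units; beyond the scatter) and a 2.3-fold lower number from compound 2 to compound 3 (0.37 log units; beyond the scatter), were both modest and show only that changes at the end of this chain have shifted the number modestly. A step of similar modest size, or none beyond the scatter, is expected here, so for compound 4 the estimate is 15000 nM, between 6000 nM and 35000 nM. That estimate means a 1.2-fold lower number from compound 3 to compound 4 (0.08 log units; within the scatter).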

Compound 4, solubility: 1000 nM
Compound 4: the middle estimate sits 15-fold (1.18 log units) above what was measured, outside the stated range (below it).
By their numbers in this assay, from the lowest: compound 4; then compound 1; then compound 3; then compound 2.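

In this assay, the carbonyl carbon at the end of this chain proved far more sensitive than the earlier changes suggested: trifluoromethyl in place of isopropoxy gave an 18-fold lower number from compound 3 to compound 4 (1.26 log units; beyond the scatter), larger than any earlier step. Two further steps, an 8.0-fold lower number from compound 1 to compound 4 (0.90 log units; beyond the scatter) and a 42-fold lower number from compound 2 to compound 4 (1.62 log units; beyond the scatter), place the trifluoromethyl amide lowest of the four. No evidence is available to explain this fall. The compounds shown leave open whether a methyl or tert-butyl group on the same carbonyl carbon, or a free amine at the chain end, would stay near compound 3 or fall toward compound 4.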